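Halogen pattern on the anilino group of the shared core

The compounds below may be only part of what the source reports. "The series", "measured", "known", "first", "only" and "open" are said of these compounds alone.

For the measured compounds named here, compound 2 `C=CC(=O)Nc1cccc(NC(=O)CSc2nc(Nc3ccc(F)c(Cl)c3)c3ccccc3n2)c1` carries the lower of the two numbers so far in a functional assay on MGC-803 cells (Homo sapiens) for inhibition, read by MTT assay, with a stated time of 72 h; on this read-out lower numbers stand for stronger inhibition and higher numbers for weaker inhibition: compound 2 gives 7850 nM, while compound 1 `C=CC(=O)Nc1cccc(NC(=O)CSc2nc(Nc3ccc(Br)cc3)c3ccccc3n2)c1` gives 11500 nM. Going by the values given here, the single measured step, a 1.5-fold lower number from compound 1 to compound 2 (0.17 log units; within the scatter), lies within the scatter, so no order between the two compounds is claimed. Compound 3 `C=CC(=O)Nc1cccc(NC(=O)CSc2nc(Nc3ccc(Cl)cc3Cl)c3ccccc3n2)c1` has not yet been measured. Its difference from compound 2 is 2,4-dichlorophenyl in place of 3-chloro-4-fluorophenyl on a nitrogen on an aromatic ring. Among the compounds with values here, the only step that bears on this change is the earlier exchange of halogens at the same place, a 1.5-fold lower number from compound 1 to compound 2 (0.17 log units; within the scatter), which stayed within the scatter; a further exchange of halogens at that place is therefore not expected to shift the number beyond the scatter in either direction. Compound 3 is expected to give about 8000 nM in this assay, within a range of 3000 nM to 20000 nM. The expected step of a 1.0-fold higher number from compound 2 to compound 3 (0.01 log units; within the scatter) is accordingly small.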

Compound 3, half-maximal inhibitory concentration: 12100 nM
Beside the measured number, compound 3's estimate is 1.5-fold (0.18 log units) below it; measured number inside the range.
By their numbers in this assay, from the lowest: compounds 2, 1 and 3 (each within the scatter of the next).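

In this assay, 2,4-dichlorophenyl in place of 3-chloro-4-fluorophenyl on a nitrogen on an aromatic ring gives a 1.5-fold higher number from compound 2 to compound 3 (0.19 log units; within the scatter) and, in place of 4-bromophenyl, gives a 1.1-fold higher number from compound 1 to compound 3 (0.02 log units; within the scatter) at the same place. A third halogen pattern, now with two chlorine atoms, thus joins the other two without any step beyond the scatter, so the three compounds cannot be put in order and halogen exchange at this place has not separated them. No measurement is available that would explain this result.

From the compounds shown here alone, all three compounds carry a halogenated phenyl here, so what an unsubstituted phenyl, or a phenyl bearing an amine, a methoxy group or a carboxylic acid, would give remains open. Going by these compounds, the rest of the shared core is identical throughout, so the effect of changes there on the number also remains open.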